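Butyl for 3-methylphenyl on the thiourea nitrogen

This account rests on a few compounds, and the source may have more. Where it says the series, first, only, none or still open, it means among the compounds named here.

The series shares one core, seen in compound 1 `COc1cc2c(cc1OC)C(=O)C(CC1CCN(C(=S)Nc3cccc(C)c3)CC1)C2`, whose activity was followed in a functional assay on the whole organism (strain Swiss albino) with Mus musculus as the target, with a stated time of 0.5 h; a lower number here means that less compound is needed, a higher number that more compound is needed for the effect. Compound 1 has no number there: for compound 1 the entry in this assay reads "not determined" (no result reported). The same holds for compound 2 `COc1cc2c(cc1OC)C(=O)C(CC1CCN(C(=S)Nc3cccc([N+](=O)[O-])c3)CC1)C2`, for which the entry in this assay reads "not determined" (no result reported). Only compound 3 `COc1cc2c(cc1OC)C(=O)C(CC1CCN(C(=S)Nc3ccc(Cl)cc3)CC1)C2` gives a number, and in this assay compound 3 gives 100 mg/kg. Going by the values given here, compound 1 therefore stands without a value of its own, and the one measured neighbour sets the scale of what the core can do.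

Compound 4 `CCCCNC(=S)N1CCC(CC2Cc3cc(OC)c(OC)cc3C2=O)CC1` is the next step. It differs from compound 1 in one place (butyl in place of 3-methylphenyl on an amide-type nitrogen). Among the compounds with values here, no measured pair shows what such a change does in this assay, so no direction can be drawn from the data, and a step no larger than the usual scatter is the plain expectation. Within the data shown here, on the single number available, from compound 3, compound 4 is expected to show about 100 mg/kg, within a range from 30 mg/kg to 300 mg/kg.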

Compound 4, minimum effective dose: 100 mg/kg
Beside the measured number, compound 4's estimate shows no gap at the digits printed, and the stated range covers the measured number.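

Going by these compounds alone, this is the first readable step at this position. In this assay, butyl in place of 4-chlorophenyl on the amide-type nitrogen gives no change at the digits printed from compound 3 to compound 4 (within the scatter), so at this position a chain with no ring can stand in for an aromatic ring without a step beyond the scatter. Going by these compounds, compound 1 and compound 2 give no single number, so steps from them cannot be read, and the effect of 3-methylphenyl or its replacement by butyl remains unknown. No available evidence bears on this result.

The compounds shown leave open whether a shorter chain such as ethyl or a longer chain such as octyl would give the same dose. They also leave open what a terminal amine or carboxylic acid on the butyl chain would do.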